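Adding an Ethyl Group to a Weak Growth Inhibitor

The compounds below may be only part of what the source reports. "The series", "measured", "known", "first", "only" and "open" are said of these compounds alone.

Three close relatives of a shared core have been measured in a functional assay on MCF7 cells (Homo sapiens) for inhibition, read by CCK-8 assay, with a stated time of 48 h; a higher number here means a weaker inhibitor of growth, a lower number a stronger inhibitor of growth. Compound 1 `Cc1ccccc1Nc1nc(Nc2ccccn2)ncc1Cl` gives 31400 nM. Compound 2 `Cc1ccccc1Nc1nc(Nc2ccc(N3CCCCC3)cn2)ncc1Cl` gives 21400 nM, and the step of a 1.5-fold lower number from compound 1 to compound 2 (0.17 log units; within the scatter) shows how little that addition changed the read-out. Compound 3 `CN1CCN(c2ccc(Nc3ncc(Cl)c(Nc4ccccc4)n3)nc2)CC1` gives 51800 nM, the highest of the three numbers; its gap to compound 1 is within the scatter, while its gap to compound 2 lies beyond it.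

Compound 4 `CCc1ccc(Nc2nc(Nc3ccc(N4CCN(C)CC4)cn3)ncc2Cl)cc1` differs from compound 3 by ethyl in place of hydrogen on an aromatic carbon, on an aromatic carbon of a six-membered aromatic ring of carbon only, para to a large group. Within the data shown here, no measured step touches this ring: the one recorded step, from compound 1 to compound 2, concerns a different ring, so it offers no direct guide. Without any relevant comparison, no step beyond the scatter is expected in this assay. The expected step is a 1.3-fold lower number from compound 3 to compound 4 (0.11 log units; within the scatter). Compound 4 is therefore estimated at 40000 nM, within 15000 nM to 110000 nM.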

Compound 4, concentration for 50% growth inhibition: 8230 nM
Estimate against measurement, compound 4: 4.9-fold (0.69 log units) above, and the stated range ends above it.
By their numbers in this assay, from the lowest: compound 4; then compounds 2, 1 and 3 (each within the scatter of the next, the first and the last beyond it).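

In this assay, the change from phenyl to 4-ethylphenyl gives a 6.3-fold lower number from compound 3 to compound 4 (0.80 log units; beyond the scatter). Among these compounds, this is the first step to lie beyond the scatter, and it shows that the read-out responds to a change on this ring, at the carbon para to a large group, where adding ethyl makes compound 4 the stronger inhibitor of growth. No measurement available here explains why ethyl has this effect.

As far as these compounds go, it remains open whether ethyl is special at this carbon, or whether a methyl group, a propyl chain, a methoxy group or an amine would shift the number as far. A single step also leaves open whether ethyl would have a similar effect in compound 1 or compound 2, which carry a different group on this ring.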